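A few compounds are considered here, and "the series" means these few. Any claim that something is new, unique, unknown or untested is made for them only; others in the source may bear on it.

Two compounds of this series have numbers in a functional assay on the whole organism with Mus musculus as the target, with a stated time of 1 h; a higher number here means that more compound is needed for the effect, a lower number that less compound is needed. Compound 1 `Cc1ccccc1-c1nnc(N(N)C(C)C)s1` gives 49 mg/kg, and compound 2 `Cc1ccccc1-c1nnc(N(C)NC(C)C)s1` gives 38 mg/kg. Compound 2 stands at the lower of the two numbers, but the step of a 1.3-fold lower number from compound 1 to compound 2 (0.11 log units; within the scatter) is within the scatter. Compound 3 `Cc1ccccc1-c1nnc(NN(C)C)s1` differs from compound 2 by (dimethylamino)amino in place of (isopropylamino)(methyl)amino on an aromatic carbon. Within the data shown here, the one measured step that bears on this side chain, a 1.3-fold lower number from compound 1 to compound 2 (0.11 log units; within the scatter), stayed within the scatter, so no step beyond the scatter is expected in this assay, in either direction. Compound 3 is expected at 45 mg/kg, with a range from 20 mg/kg to 100 mg/kg. The expected step is a 1.2-fold higher number from compound 2 to compound 3 (0.07 log units; within the scatter).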

Compound 3, dose for half-maximal effect: > 100 mg/kg
Compound 3 was reported as a limit; the forecaster's own chance of this, stated with the estimate: 5%; middle value at least 2.2-fold (0.34 log units) away from the limit.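

In this assay, among these compounds, the side chain on the aromatic carbon now makes a readable difference: (dimethylamino)amino in place of (isopropylamino)(methyl)amino gives an at least 2.6-fold higher number from compound 2 to compound 3 (0.42 log units; beyond the scatter), the first step at this position beyond the scatter. The comparison with the other side chain reads an at least 2.0-fold higher number from compound 1 to compound 3 (0.30 log units; that floor lies within the scatter), so that comparison alone does not separate the two. The value of compound 3 is a limit and not a number: the limit of > 100 mg/kg in this assay, at which 1 of the 3 values shown sits.

On these data alone, how far compound 3 lies past that limit stays open, as does whether a longer chain or a carboxylic acid on this side chain would keep the numbers of compound 1 and compound 2.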